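Lengthening the Side Chain of Compound 3

This account rests on a few compounds, and the source may have more. Where it says the series, first, only, none or still open, it means among the compounds named here.

In a functional assay on A549 cells (Homo sapiens) for antiproliferative activity, read by MTT assay, with a stated time of 48 h (a higher number here means a weaker inhibitor, a lower number a stronger inhibitor), compound 3 (`CN(C)CCn1c(N)c(-c2nc3ccccc3s2)c2nc(C#N)c(C#N)nc21`) stands at > 50000 nM as a limit of the assay and not a number (the limit of > 50000 nM in this assay, at which 1 of the 3 values shown sits). Compound 4 (`CN(C)CCCn1c(N)c(-c2nc3ccccc3s2)c2nc(C#N)c(C#N)nc21`) differs from it only in the side chain. The change ((dimethylamino)methyl in place of dimethylamino on a saturated chain carbon, two bonds along the chain from an aromatic nitrogen) places (dimethylamino)methyl in place of dimethylamino on a saturated chain carbon, two bonds along the chain from an aromatic nitrogen, so that 2-(dimethylamino)ethyl becomes 3-(dimethylamino)propyl.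

Going by the values given here, no measured step alters this chain, so the evidence is indirect. The 3-(dimethylamino)propyl chain is already carried by compound 1 (`CN(C)CCCn1c(N)c(-c2nc3ccccc3[nH]2)c2nc(C#N)c(C#N)nc21`) at 10400 nM and by compound 2 (`CN(C)CCCn1c(N)c(-c2nc3ccccc3o2)c2nc(C#N)c(C#N)nc21`) at 7170 nM in this assay alike. Among the compounds with values here, the only measured step between them is a 1.5-fold lower number from compound 1 to compound 2 (0.16 log units; within the scatter) and exchanges 1,3-benzoxazol-2-yl for 1H-benzimidazol-2-yl on an aromatic carbon. That exchange stays within the scatter, so compound 4 is expected to read close to this pair.

On these data alone, the expected move is an at least 5.5-fold lower number from compound 3 to compound 4 (0.74 log units; beyond the scatter) towards a lower number, and its true size remains open since only a limit stands at its start. In this assay compound 4 is estimated at 9000 nM within an expected range from 3000 nM to 28000 nM for repeated measurements.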

Compound 4, half-maximal inhibitory concentration: 8870 nM
Compound 4: middle estimate off by 1.0-fold (0.01 log units), on the high side; the range from low to high includes it.
By their numbers in this assay, from the lowest: compounds 2, 4 and 1 (each within the scatter of the next). At a limit, above all of these: compound 3.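

Compound 4 supplies the one step shown that alters the side chain: in this assay, going from 2-(dimethylamino)ethyl to 3-(dimethylamino)propyl with 1,3-benzothiazol-2-yl held constant gives an at least 5.6-fold lower number from compound 3 to compound 4 (0.75 log units; beyond the scatter). The full size of that step cannot be read because compound 3 stands at a limit of the assay and not at a number: the limit of > 50000 nM in this assay, at which 1 of the 4 values shown sits. With the 3-(dimethylamino)propyl chain in place, the group on the aromatic carbon makes no difference beyond the scatter, as 1,3-benzothiazol-2-yl in place of 1,3-benzoxazol-2-yl gives a 1.2-fold higher number from compound 2 to compound 4 (0.09 log units; within the scatter) and 1,3-benzothiazol-2-yl in place of 1H-benzimidazol-2-yl gives a 1.2-fold lower number from compound 1 to compound 4 (0.07 log units; within the scatter).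

Going by these compounds alone, the chain step is seen only with 1,3-benzothiazol-2-yl, so it remains open whether 2-(dimethylamino)ethyl would read the same way with 1,3-benzoxazol-2-yl or 1H-benzimidazol-2-yl on the aromatic carbon. Also open, on these data alone, is how a longer chain such as 4-(dimethylamino)butyl, or a primary amine in place of dimethylamino at the end of the chain, would read.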